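Chloro Added to the Anilino Compound: An Expected Step

The compounds below may be only part of what the source reports. "The series", "measured", "known", "first", "only" and "open" are said of these compounds alone.

Compound 1 `COc1cc(C(=O)c2sc3ccccc3c2-c2ccccc2)cc(OC)c1OC` gives 1500 nM in a functional assay on Jurkat cells (Homo sapiens) for antiproliferative activity, read by MTT assay, with a stated time of 72 h; on this read-out lower numbers stand for stronger inhibition and higher numbers for weaker inhibition. Compound 2 `COc1cc(C(=O)c2sc3ccccc3c2-c2ccc(Cl)cc2)cc(OC)c1OC` carries a single change, (chloro in place of hydrogen on an aromatic carbon), and gives 3700 nM, so that a 2.5-fold higher number from compound 1 to compound 2 (0.39 log units; beyond the scatter). Compound 3 `COc1cc(C(=O)c2sc3ccccc3c2Nc2ccccc2)cc(OC)c1OC` differs from compound 1 in its core by anilino in place of phenyl on an aromatic carbon. In this assay compound 3 gives 1600 nM; here a 1.1-fold higher number from compound 1 to compound 3 (0.03 log units; within the scatter), while a 2.3-fold lower number from compound 2 to compound 3 (0.36 log units; beyond the scatter). Compound 4 `COc1cc(C(=O)c2sc3ccccc3c2Nc2ccc(Cl)cc2)cc(OC)c1OC` has not yet been measured; it differs from compound 3 by chloro in place of hydrogen on an aromatic carbon, which is the same change as that from compound 1 to compound 2, at the same place. Because a 2.5-fold higher number from compound 1 to compound 2 (0.39 log units; beyond the scatter), a step of similar size is expected, namely a 2.4-fold higher number from compound 3 to compound 4 (0.38 log units; beyond the scatter). Compound 4 is accordingly estimated at 3800 nM, most likely between 1800 nM and 8000 nM. Since this change has been seen only once among the measured compounds, the expectation remains tentative.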

Compound 4, half-maximal inhibitory concentration: 1900 nM
Compound 4: middle estimate off by 2.0-fold (0.30 log units), on the high side, and the stated range covers the measured number.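

On the anilino core the chloro change is small, with a 1.2-fold higher number from compound 3 to compound 4 (0.07 log units; within the scatter) in this assay. Set beside the same change on the phenyl core, this step cannot be told apart from the earlier one: the same change on two cores in this assay, a 2.5-fold higher number (0.39 log units; beyond the scatter) from compound 1 to compound 2 and a 1.2-fold higher number (0.07 log units; within the scatter) from compound 3 to compound 4, 2.1-fold (0.32 log units) apart, within the scatter of two such steps. The two compounds carrying chloro also stay close when the core differs, with a 1.9-fold lower number from compound 2 to compound 4 (0.29 log units; within the scatter), and the step from the unsubstituted phenyl compound to the chloro anilino compound is small too, with a 1.3-fold higher number from compound 1 to compound 4 (0.10 log units; within the scatter), yet two pairs can neither show that chloro acts alike on both cores nor that it acts differently.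

The compounds shown leave open how a fluoro, a methyl or an amine in place of the chloro would read in this assay. They also leave open whether the chloro step would keep its size on any third core.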